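The compounds below may be only part of what the source reports. "The series", "measured", "known", "first", "only" and "open" are said of these compounds alone.

In a functional assay on BT-549 cells (Homo sapiens) for cytotoxicity, read by sulforhodamine B assay, with a stated time of 48 h (a higher number here means a weaker inhibitor of growth, a lower number a stronger inhibitor of growth), the three measured compounds gave these numbers:
compound 1 `Nc1nc(Cl)c2ncn(Cc3ccc(CCl)cc3)c2n1` gives 24600 nM;
compound 2 `ClCc1cccc(Cn2cnc3c(Cl)nc(Cl)nc32)c1` gives 3230 nM;
compound 3 `ClCc1ccc(Cn2cnc3c(Cl)nc(Cl)nc32)cc1` gives 29500 nM.

Among these, compound 2 gives the lowest number, and compound 1 and compound 3 both give higher ones. How the core of compound 2 differs from the core of compound 3 is not broken down here. Compound 3 and compound 1 differ by a single change, (amino in place of chloro on an aromatic carbon), and this change made a 1.2-fold lower number from compound 3 to compound 1 (0.08 log units; within the scatter). The unmeasured compound 4 `Nc1nc(Cl)c2ncn(Cc3cccc(CCl)c3)c2n1` arises from compound 2 by the same change, (amino in place of chloro on an aromatic carbon). A small step is expected again, estimated as a 1.1-fold lower number from compound 2 to compound 4 (0.03 log units; within the scatter), because this change once gave a 1.2-fold lower number from compound 3 to compound 1 (0.08 log units; within the scatter). Compound 4 is therefore expected to give about 3000 nM in this assay, most likely between 1200 nM and 8000 nM.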

Compound 4, concentration for total growth inhibition: 17400 nM
The estimate for compound 4 lay 5.8-fold (0.76 log units) below the measured number, outside the stated range (above it).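

In this assay, amino in place of chloro on an aromatic carbon gave a 5.4-fold higher number from compound 2 to compound 4 (0.73 log units; beyond the scatter), so the change did not carry over unchanged from one core to the other: the same change on two cores in this assay, a 1.2-fold lower number (0.08 log units; within the scatter) from compound 3 to compound 1 and a 5.4-fold higher number (0.73 log units; beyond the scatter) from compound 2 to compound 4, 6.5-fold (0.81 log units) apart, beyond the scatter of two such steps

This shows that, for these two pairs, the step seen on one core did not foretell the step on the other. It does not show why the two cores respond differently, and two pairs cannot set a rule for the whole series.

The compounds shown leave open how a methoxy group or a methylamino group at that same carbon would fare on the two cores. They also leave open whether a methyl or hydroxymethyl group in place of chloromethyl would alter this difference.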